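This account rests on a few compounds, and the source may have more. Where it says the series, first, only, none or still open, it means among the compounds named here.

Compound 3 has the structure `O=S(=O)(NC1=NCCN1C(=S)SN1CCn2c1nsc2=S)c1ccc(Cl)cc1`. In a functional assay on KYSE-510 cells (Homo sapiens) for antiproliferative activity, read by crystal violet staining, with a stated time of 96 h (a lower number here means a stronger inhibitor of growth, a higher number a weaker inhibitor of growth), compound 3 gives >= 20000 nM, and this figure is a limit of the assay rather than a measured number. Compound 1, with the structure `Cc1ccc(S(=O)(=O)NC2=NCCN2C(=S)SN2CCn3c2nsc3=S)cc1`, is the same kind of case: in this assay compound 1 gives >= 20000 nM, which is a limit. Compound 2, with the structure `O=S(=O)(NC1=NCCN1C(=S)SN1CCn2c1nsc2=S)c1ccccc1Cl`, gives >= 20000 nM in this assay, again a limit. Because (the limit of >= 20000 nM in this assay, at which 3 of the 3 values shown sit), none of the three measured compounds can be placed against the others, and the steps a step that the two limits leave unreadable from compound 1 to compound 2, a step that the two limits leave unreadable from compound 1 to compound 3 and a step that the two limits leave unreadable from compound 2 to compound 3 are all left unreadable.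

Compound 4 has the structure `O=S(=O)(NC1=NCCN1C(=S)SN1CCn2c1nsc2=S)c1cc(Cl)cc(Cl)c1`. The change from compound 3 to compound 4 is 3,5-dichlorophenyl in place of 4-chlorophenyl on a sulfonyl sulfur. All three measured steps bear on this change in the sense that each of them alters the aryl group on the sulfonyl sulfur, yet none of them gave a readable size, so there is no measured guide to how large a step to expect. Given that compound 3 sits at a limit, the expected step of a number no higher from compound 3 to compound 4 (the limit leaves the size open) is no step beyond the scatter, and compound 4 is expected to give about 20000 nM, within the range 7000 nM to 60000 nM, most likely again reported only as a limit.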

Compound 4, concentration for 50% growth inhibition: >= 20000 nM
Compound 4 was reported as a limit; the forecaster's own chance of this, stated with the estimate: 80%; the middle value lies on the limit itself.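

In this assay compound 4 gives >= 20000 nM, which is a limit of the assay. For the compounds shown here, no step from compound 1, compound 2 or compound 3 to compound 4 can be read, because all four compounds share one limit: the limit of >= 20000 nM in this assay, at which 4 of the 4 values shown sit. The compounds shown leave open whether these aryl groups on the sulfonyl sulfur differ at all in growth inhibition.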